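The source may report more compounds than this note shows. Statements on the series, on what has been measured and on what is new or still open speak of the compounds shown alone.

Three close relatives have been tested so far in a functional assay on HGC-27 cells (Homo sapiens) for cytotoxicity, read by MTT assay, with a stated time of 48 h; a lower number here means a stronger inhibitor, a higher number a weaker inhibitor: compound 1 `COc1ccc(/C=C/C(=O)/C=C/c2cc3ccccc3nc2Oc2ccccc2)c(OC)c1`, compound 2 `COc1ccc(/C=C/C(=O)/C=C/c2cc3ccccc3nc2Oc2ccccc2)cc1OC` and compound 3 `COc1cc(OC)c(/C=C/C(=O)/C=C/c2cc3ccccc3nc2Oc2ccccc2)c(OC)c1`. Compound 1 gives > 10000 nM, which is a limit of the assay and not a number. Compound 2 gives > 10000 nM, again a limit. Compound 3 gives > 10000 nM, also a limit. Compound 1 therefore has no exact place on the scale, and the whole picture so far is the limit of > 10000 nM in this assay, at which 3 of the 3 values shown sit.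

Compound 4 `COc1ccc(/C=C/C(=O)/C=C/c2cc3ccccc3nc2Oc2cccc(Cl)c2)c(OC)c1` keeps the core of compound 1 and turns its phenoxy group into 3-chlorophenoxy: chloro in place of hydrogen on an aromatic carbon. Two measured steps start from compound 1. One is a step that the two limits leave unreadable from compound 1 to compound 2, and the other is a step that the two limits leave unreadable from compound 1 to compound 3. Neither step alters the phenoxy group, and neither has a size that can be read, so they offer no measured guide to the effect of adding chloro. Going by the values given here, the only firm guidance is that all three relatives sit at the same limit in this assay, so no large gain is expected. The estimated step, a number no higher from compound 1 to compound 4 (the limit leaves the size open), is small at best, and another limit would be no surprise. Compound 4 is expected to read about 10000 nM, within an estimated range from 3000 nM to 30000 nM.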

Compound 4, half-maximal inhibitory concentration: > 10000 nM
Compound 4 gave a limit, no number; the forecaster's own chance of this, stated with the estimate: 60%; the middle value lies on the limit itself.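

Compound 1 and compound 4 both end at a limit of the assay and not at a number, so the change from phenoxy to 3-chlorophenoxy has no size that can be read. How strong any of these compounds truly is, and whether any change in this series gives a readable value in this assay, stays open: the limit of > 10000 nM in this assay, at which 4 of the 4 values shown sit.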